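A few compounds are considered here, and "the series" means these few. Any claim that something is new, unique, unknown or untested is made for them only; others in the source may bear on it.

In a functional assay on HUVEC cells (Homo sapiens) for inhibition, with a stated time of 4 days (a higher number here means a weaker inhibitor, a lower number a stronger inhibitor), compound 1 (`COc1ccc(C(N)=O)cc1/C=C/c1ccc(Cl)cc1`) gives 87 nM and compound 2 (`COc1ccc(C(N)=O)cc1/C=C/c1ccccc1Cl`) gives 23000 nM, the higher of the two numbers and beyond the scatter. Compound 3 (`COc1ccc(C(N)=O)cc1/C=C/c1ccc(Cl)cc1Cl`) differs from compound 2 in one place: chloro in place of hydrogen on an aromatic carbon, meta to a chloro group and para to a large group. Compound 1, at 87 nM, also carries a chloro para to a large group, so a large drop in this assay is expected. The expected step is a 15-fold lower number from compound 2 to compound 3 (1.19 log units; beyond the scatter). The estimate for compound 3 is 1500 nM, with an expected range of 150 nM to 15000 nM.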

Compound 3, half-maximal inhibitory concentration: 2600 nM
Estimate against measurement, compound 3: 1.7-fold (0.24 log units) below, and the stated range covers the measured number.
By their numbers in this assay, from the lowest: compound 1; then compound 3; then compound 2.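

In this assay, the chloro para to a large group helps even on the weak background of compound 2, with an 8.8-fold lower number from compound 2 to compound 3 (0.95 log units; beyond the scatter) as the step. Yet a 30-fold higher number from compound 1 to compound 3 (1.48 log units; beyond the scatter) is the step when the chloro of compound 2 is added to compound 1, so the new chloro recovers only part of what that other chloro costs. Nothing available explains either step.

Open, as far as these compounds go, is whether a methyl, a methoxy or an amine at this position would lower the number as chloro does. Also open, from the compounds shown here alone, is whether the cost of the other chloro is specific to chlorine.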